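Methyl on a Saturated Ring Carbon and Cytotoxicity Limits

The source may hold more compounds than are shown below. What is called first, only, known or untested is meant among the compounds shown, and "the series" means these compounds.

Four compounds are considered. Compound 1 `O=C(NCC1CCn2cc([N+](=O)[O-])nc2O1)Nc1ccc(OC(F)(F)F)cc1` and compound 2 `CC1(CNC(=O)Nc2ccc(OC(F)(F)F)cc2)CCn2cc([N+](=O)[O-])nc2O1` share one core, while compound 3 `O=C(NCc1ccc(OC(F)(F)F)cc1)N(Cc1ccc(OC(F)(F)F)cc1)C(=O)OCC1CCn2cc([N+](=O)[O-])nc2O1` and compound 4 `CC1(COC(=O)N(Cc2ccc(OC(F)(F)F)cc2)C(=O)NCc2ccc(OC(F)(F)F)cc2)CCn2cc([N+](=O)[O-])nc2O1` share another; the difference between the two cores is not broken down here. In an ADME assay on MRC5 cells (Homo sapiens) for cytotoxicity, read by resazurin assay, with a stated time of 72 h (on this read-out lower numbers stand for stronger inhibition and higher numbers for weaker inhibition), compound 1 gives >= 40000 nM, which is a limit of the assay. Compound 2 gives >= 40000 nM in this assay, also a limit. Compound 3 gives >= 40000 nM in this assay, again a limit. The change from compound 1 to compound 2 is methyl in place of hydrogen on a saturated ring carbon, and its step that the two limits leave unreadable from compound 1 to compound 2 cannot be read because of the limit of >= 40000 nM in this assay, at which 3 of the 3 values shown sit. The same change, (methyl in place of hydrogen on a saturated ring carbon), carries compound 3 to compound 4. Compound 4 is expected to show a step that the limit leaves unreadable from compound 3 to compound 4 because a step that the two limits leave unreadable from compound 1 to compound 2 was unreadable and (the limit of >= 40000 nM in this assay, at which 3 of the 3 values shown sit). Compound 4 is therefore estimated at 60000 nM in this assay.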

Compound 4, half-maximal inhibitory concentration: >= 40000 nM
Compound 4 ended at the assay's limit (the forecaster's own chance of this, stated with the estimate: 85%); the middle value lies beyond the limit too.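

No step can be read from compound 3 to compound 4, as both sit at a limit: the limit of >= 40000 nM in this assay, at which 4 of the 4 values shown sit.

The compounds shown leave open whether methyl in place of hydrogen on a saturated ring carbon shifts the read-out in this assay at all.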